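Sulfur-to-nitrogen substituent swap on the shared core

The compounds below may be only part of what the source reports. "The series", "measured", "known", "first", "only" and "open" are said of these compounds alone.

Going by the values given here, compound 2 `OC[C@@H]1O[C@@H](n2c(SCc3ccccc3)nc3cc(Cl)c(Cl)cc32)[C@H](O)[C@@H]1O` gives 40000 nM in a functional assay on KB cells (Homo sapiens) for inhibition (a higher number here means a weaker inhibitor, a lower number a stronger inhibitor), the only number in the set so far. Compound 1 `OC[C@@H]1O[C@@H](n2c(S)nc3cc(Cl)c(Cl)cc32)[C@H](O)[C@@H]1O` reaches only a limit, > 100000 nM, in this assay. Among the compounds with values here, the one measured step, an at least 2.5-fold lower number from compound 1 to compound 2 (0.39 log units; beyond the scatter), shows that the group on the sulfur moves the read-out, with one end resting at the limit of > 100000 nM in this assay, at which 1 of the 2 values shown sits. Compound 3 `CCCNc1nc2cc(Cl)c(Cl)cc2n1[C@@H]1O[C@@H](CO)[C@@H](O)[C@H]1O` differs from compound 2 as propylamino in place of benzylsulfanyl on an aromatic carbon. Within the data shown here, no measured step trades the sulfur link for a nitrogen link or shortens the chain, so direction is uncertain and a change within scatter is the default. Compound 3 is expected near 60000 nM, between 15000 nM and 200000 nM. The expected step is therefore a 1.5-fold higher number from compound 2 to compound 3 (0.18 log units; within the scatter), possibly ending at the limit.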

Compound 3, half-maximal inhibitory concentration: > 100000 nM
Compound 3: only a limit was reported; the forecaster's own chance of this, stated with the estimate: 35%; middle value at least 1.6-fold (0.22 log units) from the limit.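

In this assay, the benzylsulfanyl group on this aromatic carbon, between two ring nitrogen atoms, proves better than propylamino: an at least 2.5-fold higher number from compound 2 to compound 3 (0.39 log units; beyond the scatter). So this position tolerates a swap of link and chain together less well than the single step from compound 1 could show. The step between compound 1 and compound 3 cannot be read, as both values are limits: the limit of > 100000 nM in this assay, at which 2 of the 3 values shown sit.

The swap changes the sulfur link, the chain and the aromatic ring at once, so their shares stay unresolved. Benzylamino and propylsulfanyl groups would separate the link from the chain.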